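Ester size and plasma half-life: from ethyl to cyclopentylmethyl

The compounds below may be only part of what the source reports. "The series", "measured", "known", "first", "only" and "open" are said of these compounds alone.

Compound 1 `COC(=O)c1cccc(-c2cc(C(=O)Nc3ccncc3)ccc2CN)c1`: 1.52 h
Compound 2 `CC(C)OCCOC(=O)c1cccc(-c2cc(C(=O)Nc3ccncc3F)ccc2CN)c1`: 0.1 h
Compound 3 `CCOC(=O)c1cccc(-c2cc(C(=O)Nc3ccncc3)ccc2CN)c1`: 0.683 h

In an ADME assay on a cell-free system (plasma, Homo sapiens) for metabolic stability, read by LC-MS (a lower number here means that the compound disappears faster, a higher number that the compound lasts longer), compound 3 stands second highest of the three numbers, nearest to compound 1 and furthest from compound 2. Compound 4 `NCc1ccc(C(=O)Nc2ccncc2)cc1-c1cccc(C(=O)OCC2CCCC2)c1` differs from it by cyclopentyl in place of methyl on a saturated chain carbon bound to an oxygen next to a carbonyl group. Among the compounds with values here, the one measured step on that position, a 2.2-fold lower number from compound 1 to compound 3 (0.35 log units; beyond the scatter), shows the half-life falling as the ester grows, and compound 2, which carries a larger ester together with a second change, gives the lowest number of all. A further and larger enlargement of the ester is therefore expected to lower the half-life again, by about a 2.3-fold lower number from compound 3 to compound 4 (0.36 log units; beyond the scatter). Compound 4 is estimated at 0.3 h, with a range from 0.1 h to 0.9 h.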

Compound 4, half-life: 0.517 h
Compound 4: the middle estimate sits 1.7-fold (0.24 log units) below what was measured; measured number inside the range.
By their numbers in this assay, from the lowest: compound 2; then compounds 4 and 3 (each within the scatter of the next); then compound 1.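

In this assay, cyclopentyl in place of methyl on a saturated chain carbon bound to an oxygen next to a carbonyl group gives only a small step (a 1.3-fold lower number from compound 3 to compound 4 (0.12 log units; within the scatter)), so this much larger group does not clearly extend the trend set by the first added methyl. Counted from the hydrogen, the same position still shows a real change (a 2.9-fold lower number from compound 1 to compound 4 (0.47 log units; beyond the scatter)). Nothing available here explains this result.

The compounds shown leave open whether a longer straight chain or an amine at this place would match cyclopentyl. Compound 2 differs in more than one place, so it cannot settle this.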